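The source may hold more compounds than are shown below. What is called first, only, known or untested is meant among the compounds shown, and "the series" means these compounds.

Measured so far in a functional assay on ileum for antagonist activity at histamine H1 receptor (Cavia porcellus); on this read-out higher numbers stand for weaker binding and lower numbers for tighter binding:
compound 1, `CCC(=O)/N=C(\N)NCCCc1c[nH]cn1`: 5130 nM
compound 2, `CC(C)C(=O)/N=C(\N)NCCCc1c[nH]cn1`: 7760 nM

In this assay compound 2 gives the higher of the two numbers, but the step of a 1.5-fold higher number from compound 1 to compound 2 (0.18 log units; within the scatter) lies within the scatter, so the two compounds are not separated. Compound 3, `CCCC(=O)/N=C(\N)NCCCc1c[nH]cn1`, differs from compound 2 by propyl in place of isopropyl on a carbonyl carbon. Among the compounds with values here, the only measured step that bears on this change at the acyl group is a 1.5-fold higher number from compound 1 to compound 2 (0.18 log units; within the scatter), which moved nothing beyond the scatter. No shift beyond the scatter is therefore expected for the move from compound 2 to compound 3, a 1.2-fold lower number from compound 2 to compound 3 (0.08 log units; within the scatter). Compound 3 is estimated at 6500 nM, with a range of 2500 nM to 17000 nM.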

Compound 3, dissociation constant: 3550 nM
The estimate for compound 3 lay 1.8-fold (0.26 log units) above the measured number, within the range that was stated.
By their numbers in this assay, from the lowest: compounds 3, 1 and 2 (each within the scatter of the next, the first and the last beyond it).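

In this assay the acyl group gives its first step beyond the scatter: propyl in place of isopropyl on a carbonyl carbon gives a 2.2-fold lower number from compound 2 to compound 3 (0.34 log units; beyond the scatter) as a modest shift, with the same atoms joined differently. Methyl in place of hydrogen on a saturated chain carbon, two bonds along the chain from a carbonyl carbon, gives a 1.4-fold lower number from compound 1 to compound 3 (0.16 log units; within the scatter) and so compound 1 is separated from neither compound 2 nor compound 3. Nothing available gives a reason for the shift. Open, as far as these compounds go, is whether a longer chain or a phenyl group on the carbonyl carbon would move the number beyond the scatter from that of compound 1.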